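The source may hold more compounds than are shown below. What is called first, only, known or untested is meant among the compounds shown, and "the series" means these compounds.

Working notes on the series. Two halogenated analogues have been measured in an ADME assay on HPLF cells (Homo sapiens) for cytotoxicity, with a stated time of 48 h; a lower number here means that less compound is tolerated, a higher number that more compound is tolerated. Compound 1 `Cc1c(C(=O)/C=C/c2ccc(Cl)cc2)[n+]([O-])c2ccccc2[n+]1[O-]` gives 12000 nM in this assay. Compound 2 `Cc1c(C(=O)/C=C/c2ccc(F)cc2)[n+]([O-])c2ccccc2[n+]1[O-]` gives 20000 nM in this assay. Among the measured compounds shown here, the only step so far, fluoro in place of chloro on an aromatic carbon, reads a 1.7-fold higher number from compound 1 to compound 2 (0.22 log units; within the scatter). For the measured compounds named here, compound 2 therefore holds the upper of the two numbers in this assay, but its only neighbour, compound 1, sits within the scatter of it, so no separation is established.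

Compound 3 `Cc1c(C(=O)/C=C/c2ccc(Br)cc2)[n+]([O-])c2ccccc2[n+]1[O-]` is not yet measured. It differs from compound 2 by bromo in place of fluoro on an aromatic carbon. Going by the values given here, the one step that bears on this, the halogen exchange from compound 1 to compound 2, was within the scatter, so no step beyond the scatter is expected in this assay in either direction. For compound 3 the expected value in this assay is 14000 nM (range 6000 nM to 35000 nM), which means an expected step of a 1.4-fold lower number from compound 2 to compound 3 (0.15 log units; within the scatter).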

Compound 3, half-maximal cytotoxic concentration: 26000 nM
Compound 3: the middle estimate sits 1.9-fold (0.27 log units) below what was measured; the range from low to high includes it.
By their numbers in this assay, from the lowest: compounds 1, 2 and 3 (each within the scatter of the next, the first and the last beyond it).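

In this assay, bromo in place of fluoro at this position, on an aromatic carbon para to a large group, gives a 1.3-fold higher number from compound 2 to compound 3 (0.11 log units; within the scatter), so this exchange, like the first, does not separate its pair. Bromo in place of chloro at the same position gives a 2.2-fold higher number from compound 1 to compound 3 (0.34 log units; beyond the scatter), the first step in the series beyond the scatter, though only a modest one, so the three halogens together span a small but readable difference. Nothing at hand accounts for this step.

The compounds shown carry only halogens at this position, so a methoxy group, an amine or a carboxylic acid there remains an open question. Also open, going by these compounds, is whether these halogen steps would read the same with a longer chain in place of the methyl group on the shared core.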